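Trimming the Amine in a Series Without Cytotoxicity

This account rests on a few compounds, and the source may have more. Where it says the series, first, only, none or still open, it means among the compounds named here.

Compound 3 `CCOCCOC(=O)Nc1cc2nc(C3CCCCC3)[nH]c2cc1N(CC)CC` carries a diethylamino group and an ((2-ethoxyethoxy)carbonyl)amino group on the shared core. In an ADME assay on Vero cells (Chlorocebus sabaeus) for cytotoxicity, read by resazurin assay, with a stated time of 3 days (a lower number here means a stronger inhibitor, a higher number a weaker inhibitor), compound 3 gives only a limit, > 100 ug/mL. Compound 1 `CN(C)c1cc2[nH]c(C3CCCCC3)nc2cc1NC(=O)c1ccco1` also gives a limit in this assay, > 100 ug/mL. Compound 2 `Cc1ccc(C(=O)Nc2cc3nc(C4CCCCC4)[nH]c3cc2N(C)C)cc1` likewise gives a limit in this assay, > 100 ug/mL. Among the compounds with values here, the single step between measured compounds that differ in one place, a step that the two limits leave unreadable from compound 1 to compound 2, cannot be sized, and the sole evidence across the set is the limit of > 100 ug/mL in this assay, at which 3 of the 3 values shown sit. Compound 4 `CCOCCOC(=O)Nc1cc2nc(C3CCCCC3)[nH]c2cc1N(C)C` differs from compound 3 by the change (dimethylamino in place of diethylamino on an aromatic carbon). Within the data shown here, no measured step bears directly on this exchange, as diethylamino against dimethylamino has not been compared here. Because every measured value sits at the limit of > 100 ug/mL in this assay, at which 3 of the 3 values shown sit, no step beyond the scatter is expected from compound 3 to compound 4. The expected step is a step that the limit leaves unreadable from compound 3 to compound 4. Compound 4 is therefore expected to give about 150 ug/mL in this assay, within 80 ug/mL to 400 ug/mL, and most likely to be reported again only as a limit.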

Compound 4, half-maximal inhibitory concentration: > 100 ug/mL
Compound 4: only a limit was reported (the forecaster's own chance of this, stated with the estimate: 85%); the middle value does not contradict the limit.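

In this assay compound 4 gives > 100 ug/mL as a limit. Compound 1, compound 2 and compound 3 also give only limits, so no new step to compound 4 can be read: the limit of > 100 ug/mL in this assay, at which 4 of the 4 values shown sit.

The compounds shown leave open whether this assay would return a readable number for any change on the shared core.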